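The source may report more compounds than this note shows. Statements on the series, on what has been measured and on what is new or still open speak of the compounds shown alone.

Compound 1 `CNC(=O)c1cc(Oc2ccc(NC(=O)c3cc4cccnc4n(-c4ccccc4F)c3=O)cc2)ccn1` gives 610 nM in a functional assay on A549 cells (Homo sapiens) for antiproliferative activity, read by MTT assay, with a stated time of 72 h; a lower number here means a stronger inhibitor, a higher number a weaker inhibitor.
Compound 2 `CNC(=O)c1cc(Oc2ccc(NC(=O)c3cc4cccnc4n(-c4ccc(F)cc4)c3=O)cc2)ccn1` gives 110 nM in this assay.

Among the compounds with values here, of these two numbers, compound 1 holds the higher one; the single measured step, a 5.5-fold lower number from compound 1 to compound 2 (0.74 log units; beyond the scatter), is modest and lies beyond the scatter. It concerns the fluorophenyl on the aromatic nitrogen and nothing else.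

Compound 3 `CCNC(=O)c1cc(Oc2ccc(NC(=O)c3cc4cccnc4n(-c4ccccc4F)c3=O)cc2)ccn1` differs from compound 1 by methyl in place of hydrogen on a saturated chain carbon bound to an amide-type nitrogen, the same difference read one bond further out as methylcarbamoyl to ethylcarbamoyl. Within the data shown here, no measured step touches this part of the molecule: the one step in hand changes the fluorophenyl, and the carbamoyl chain is the same in compound 1 and compound 2. With nothing to carry over, the expected outcome is no step beyond the scatter, no change at the digits printed from compound 1 to compound 3 (within the scatter). Compound 3 is therefore estimated at 610 nM, with a range from 200 nM to 1900 nM.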

Compound 3, half-maximal inhibitory concentration: 490 nM
Compound 3: the middle estimate sits 1.2-fold (0.10 log units) above what was measured; the measured number falls inside the stated range.
By their numbers in this assay, from the lowest: compound 2; then compounds 3 and 1 (each within the scatter of the next).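

Within the data shown here, the step of a 1.2-fold lower number from compound 1 to compound 3 (0.10 log units; within the scatter) in this assay is the only reading on the carbamoyl chain, and it shows that going from methylcarbamoyl to ethylcarbamoyl, with the 2-fluorophenyl kept, does not separate compound 3 from compound 1. The one other step, a 5.5-fold lower number from compound 1 to compound 2 (0.74 log units; beyond the scatter), lies on the fluorophenyl and goes beyond the scatter, so among these compounds only that change moves the number measurably. No measured evidence bears on why the added methyl leaves the number within the scatter.

From the compounds shown here alone, whether the ethylcarbamoyl chain would give the same outcome alongside the 4-fluorophenyl of compound 2 remains open. So does what a longer chain such as propyl, a cyclopropyl ring or a terminal amine would do at this position.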